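The compounds below may be only part of what the source reports. "The series", "measured", "known", "first", "only" and "open" are said of these compounds alone.

Measured in an ADME assay on Vero cells (Chlorocebus sabaeus) for cytotoxicity, read by MTT assay, with a stated time of 96 h; on this read-out lower numbers stand for higher toxicity in this test and higher numbers for lower toxicity in this test:
- compound 1 `COc1ccc(-c2nc3cc(C(C)=O)ccc3[nH]2)c(OC)c1`: > 100000 nM
- compound 2 `COc1ccc(-c2nc3cc(C(C)=O)ccc3[nH]2)c(OC)c1OC`: > 100000 nM
- compound 3 `COc1ccc(-c2nc3cc(C(C)O)ccc3[nH]2)c(OC)c1OC`: >= 100000 nM

In this assay compound 1 gives > 100000 nM, which is a limit of the assay and not a number. The same holds for the other two compounds, so there is no exact reading to compare: the limit of > 100000 nM in this assay, at which 2 of the 3 values shown sit, and (the limit of >= 100000 nM in this assay, at which 1 of the 3 values shown sits).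

Compound 4 `COc1ccc(-c2nc3cc(/C(C)=N/O)ccc3[nH]2)c(OC)c1` differs from compound 1 in one place, on an aromatic carbon, where the acetyl leaves: a group of 4 heavy atoms (2 carbon, 1 nitrogen, 1 oxygen; no ring) in place of a group of 3 heavy atoms (2 carbon, 1 oxygen; no ring), on an aromatic carbon.

The closest measured change also replaces the acetyl, and 1-hydroxyethyl in its place gives a step that the two limits leave unreadable from compound 2 to compound 3. Methoxy in place of hydrogen, at a different place, gives a step that the two limits leave unreadable from compound 1 to compound 2. Neither step has a size that can be carried over to the new change. Still, no change so far has brought a reading under the limit. Compound 3, which carries no acetyl, remains at >= 100000 nM, and this too is a limit.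

The estimated step is a number no higher from compound 1 to compound 4 (the limit leaves the size open), so no shift beyond the usual scatter is expected in either direction, and another limit is the likeliest report. The expected value for compound 4 is 100000 nM, with an estimated range from 40000 nM to 150000 nM.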

Compound 4, half-maximal cytotoxic concentration: > 100000 nM
Compound 4: no number, only a limit; the forecaster's own chance of this, stated with the estimate: 75%; the middle value sits exactly at the limit.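

In this assay compound 4 gives > 100000 nM, which is a limit of the assay and not a number. Compound 1 also sits at a limit, so the step from compound 1 to compound 4 cannot be read. The compounds shown leave open at what concentration, if any, each of the four would harm the cells.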